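Methyl in place of methoxy: what to expect for compound 4

The compounds below may be only part of what the source reports. "The series", "measured", "known", "first", "only" and "open" are said of these compounds alone.

Of the compounds shown here, three of the shared core have been measured in an ADME assay on Vero cells (Chlorocebus sabaeus) for cytotoxicity, read by neutral red uptake, tested at 98 ug/mL; a lower number here means a stronger effect, a higher number a weaker effect of the compound at the concentration tested: compound 1 `O=C1CSC(c2c(Cl)cccc2Cl)N1CCN1CCCCC1` gives 76%, compound 2 `COc1ccc(C2SCC(=O)N2CCN2CCCCC2)cc1` gives 89%, and compound 3 `COc1cccc(C2SCC(=O)N2CCN2CCCCC2)c1` gives 84%. Compound 2 shows the largest of the three numbers; compound 3 falls within the usual scatter of it, whereas compound 1 lies beyond the scatter.

Compound 4 `Cc1ccc(C2SCC(=O)N2CCN2CCCCC2)cc1` has not been measured. It differs from compound 2 by methyl in place of methoxy on an aromatic carbon. Among the measured compounds shown here, no pair of measured compounds isolates this change, so the expectation rests on compound 2 alone. The expected step is a number 4 percentage points lower from compound 2 to compound 4 (within the scatter), not beyond the scatter in either direction. For compound 4 the estimate in this assay is 85%, with a range from 72% to 96%.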

Compound 4, a percentage reported as activity, at one concentration (the size of the read-out at that concentration, not a potency): 100%
Compound 4: middle estimate off by 15 percentage points, on the low side, outside the stated range (above it).
By their numbers in this assay, from the lowest: compounds 1, 3 and 2 (each within the scatter of the next, the first and the last beyond it); then compound 4.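

Among the compounds shown here, this is the first step that isolates one place: in this assay, methyl in place of methoxy gives a number 11 percentage points higher from compound 2 to compound 4 (beyond the scatter). The read-out therefore responds to the group on this aromatic carbon, para to a large group, and the change removes the oxygen and the hydrogen-bond acceptor of methoxy. Nothing available bears on the reason for the step.

Still open, as far as these compounds go, is how an ethyl chain, an amine or a carboxylic acid on this carbon would read. Also open, from the compounds shown here alone, is whether the same change would give a similar step where compound 3 carries its methoxy.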